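The source may hold more compounds than are shown below. What is called first, only, known or untested is meant among the compounds shown, and "the series" means these compounds.

Measured compounds in a functional assay on HEK293 cells for positive allosteric modulation of metabotropic glutamate receptor 5 (Homo sapiens), read by calcium flux; a higher number here means a larger maximal response, a lower number a smaller maximal response:
- compound 1 `O=C1c2cc(COc3ccccc3)nn2CCN1c1cccc(F)c1`: 81%
- compound 2 `O=C1c2cc(COc3ccccc3)nn2CCN1c1ccc(F)cc1F`: 101%

Compound 2 stands highest of the two numbers in this assay, with compound 1 the nearest and lower, a gap that lies beyond the scatter: a number 20 percentage points higher from compound 1 to compound 2 (beyond the scatter).

Compound 3 `O=C1c2cc(COc3ccccc3)nn2CCN1c1cccnc1` differs from compound 2 in the group attached to the amide-type nitrogen in the ring: pyridin-3-yl in place of 2,4-difluorophenyl on an amide-type nitrogen in a ring. Among the measured compounds shown here, the only measured step, a number 20 percentage points higher from compound 1 to compound 2 (beyond the scatter), concerns a change in fluorine count and placement on a phenyl group on the same nitrogen, and it was modest. For the measured compounds named here, it shows that this position tolerates variation, but no measured compound carries a pyridin-3-yl or any ring with a nitrogen here, so its direction gives little guidance for compound 3. Losing both fluorines and gaining a hetero atom is a larger change than the one measured, and the likelier outcome is a somewhat smaller maximal response than compound 2 rather than a larger one, though a result within the scatter is plausible. For compound 3 the expected value in this assay is 85%, with a range of 55% to 110%, which corresponds to an expected step of a number 16 percentage points lower from compound 2 to compound 3 (beyond the scatter).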

Compound 3, largest response reached (Emax), in percent of the reference or control that the assay uses: 64%
For compound 3 the middle estimate is 21 percentage points above the measured one, and the stated range covers the measured number.
By their numbers in this assay, from the lowest: compound 3; then compound 1; then compound 2.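

In this assay the group on the amide-type nitrogen in the ring turns out to matter more than the fluorine change alone suggested: pyridin-3-yl in place of 2,4-difluorophenyl gives a number 37 percentage points lower from compound 2 to compound 3 (beyond the scatter) and this is the largest step among the three compounds. The same group in place of 3-fluorophenyl gives a number 17 percentage points lower from compound 1 to compound 3 (beyond the scatter) and so, among these three compounds and with none going against it, both fluorinated phenyl groups give a larger maximal response than the ring holding a nitrogen atom. Nothing measured here explains this drop, so its cause remains unknown.

Two things changed at once in this swap, the fluorine atoms left and a ring nitrogen entered, and the compounds shown cannot separate them; a plain phenyl group on the same nitrogen would help to do that. Pyridin-2-yl and pyridin-4-yl would show whether the place of the ring nitrogen counts, and a fluorinated pyridin-3-yl would show whether fluorine can restore the response.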